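Piperidin-4-yl in place of phenyl: an inactive starting point

The source may hold more compounds than are shown below. What is called first, only, known or untested is meant among the compounds shown, and "the series" means these compounds.

Measured so far:
compound 1 `COc1ccc(-c2noc(-c3ccccc3)n2)cc1OC1CCCC1` — > 1000000 nM
compound 2 `COc1ccc(-c2noc(-c3ccc(F)cc3)n2)cc1O` — > 1000000 nM

Both measured values in a functional assay on DU-145 cells (Homo sapiens) for antiproliferative activity, read by MTT assay, with a stated time of 24 h (a higher number here means a weaker inhibitor, a lower number a stronger inhibitor), are limits of the assay rather than numbers. For compound 1 the value > 1000000 nM is such a limit. For compound 2 the value > 1000000 nM is likewise a limit. Compound 1 therefore stands at the limit, and the whole picture so far is the limit of > 1000000 nM in this assay, at which 2 of the 2 values shown sit. For the measured compounds named here, no step between measured compounds can be drawn, since compound 1 and compound 2 differ in more than one place.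

Compound 3 `COc1ccc(-c2noc(C3CCNCC3)n2)cc1OC1CCCC1` is not yet measured. It differs from compound 1 by piperidin-4-yl in place of phenyl on an aromatic carbon. Going by the values given here, nothing measured here bears on that change; the only evidence is the limit of > 1000000 nM in this assay, at which 2 of the 2 values shown sit. The expected step is a number no higher from compound 1 to compound 3 (the limit leaves the size open), that is, none beyond the scatter, with the result again at the limit. Compound 3 is estimated at 1000000 nM in this assay, in the range 100000 nM to 3000000 nM, with the most probable outcome being another limit rather than a number.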

Compound 3, half-maximal inhibitory concentration: 57 nM
Estimate against measurement, compound 3: 18000-fold (4.24 log units) above; the whole stated range lies above it.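

In this assay, the aromatic carbon of the five-membered aromatic ring, next to the ring nitrogen and the ring oxygen, proves sensitive to the group it bears: piperidin-4-yl in place of phenyl gives an at least 17000-fold lower number from compound 1 to compound 3 (4.24 log units; beyond the scatter). Compound 1 gives > 1000000 nM, which is a limit of the assay, so the full size of this step cannot be read. Compound 3 is the only compound shown that leaves this limit, and the change keeps the heavy-atom count while replacing an aromatic ring of carbon only with a non-aromatic ring holding one nitrogen, which brings a hydrogen-bond donor and acceptor: the limit of > 1000000 nM in this assay, at which 2 of the 3 values shown sit.

The compounds shown do not separate the contribution of the ring nitrogen from that of losing the aromatic ring, a question that a cyclohexyl group on the same carbon would address. Also open, as far as these compounds go, is whether the ring itself matters, which an open aminoalkyl chain ending in a primary amine, or a piperidin-4-yl with a methyl group on its nitrogen, would test.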